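The compounds below may be only part of what the source reports. "The series", "measured", "known", "first", "only" and "open" are said of these compounds alone.

- Compound 1 `Cc1cnc(Nc2ccc(C#N)cc2)nc1Nc1c(F)cc(-c2cncnc2)cc1F`: 900 nM
- Compound 2 `Cc1cnc(Nc2ccc(C#N)cc2)nc1Nc1c(F)cc(-c2ccoc2)cc1F`: 4200 nM

In a toxicity assay on MT4 cells (Homo sapiens) for cytotoxicity, read by MTT assay, with a stated time of 5 days (a higher number here means that more compound is tolerated, a lower number that less compound is tolerated), compound 2 has the higher of the two numbers, so it sits at the tolerated end of this small set. Compound 3 `Cc1cnc(Nc2ccc(C#N)cc2)nc1Nc1c(F)cc(-c2cccs2)cc1F` has not yet been measured. It has thiophen-2-yl in place of furan-3-yl on an aromatic carbon.

Within the data shown here, only one measured step bears on this position, a 4.7-fold higher number from compound 1 to compound 2 (0.67 log units; beyond the scatter), and it came from replacing pyrimidin-5-yl with furan-3-yl. The new change is a closer swap, since one five-membered aromatic ring with 1 hetero atom replaces another. Among the measured compounds shown here, no measured step shows what exchanging oxygen for sulfur does, so only a small shift is expected in this assay, slightly downward if anything and not beyond the scatter: the estimate is a 1.4-fold lower number from compound 2 to compound 3 (0.15 log units; within the scatter). For compound 3, the expected value is 3000 nM, with an estimated range of 1000 nM to 9000 nM.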

Compound 3, half-maximal cytotoxic concentration: 8000 nM
Compound 3: middle estimate off by 2.7-fold (0.43 log units), on the low side; the range from low to high includes it.
By their numbers in this assay, from the lowest: compound 1; then compounds 2 and 3 (each within the scatter of the next).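

In this assay, exchanging the oxygen ring furan-3-yl for the sulfur ring thiophen-2-yl gives a 1.9-fold higher number from compound 2 to compound 3 (0.28 log units; within the scatter) and so does not separate these two five-membered rings. The other new comparison, with pyrimidin-5-yl, gives an 8.9-fold higher number from compound 1 to compound 3 (0.95 log units; beyond the scatter) and shows that furan-3-yl is no lone case: two different five-membered aromatic rings with 1 hetero atom now both allow more compound to be tolerated than pyrimidin-5-yl does. No outside evidence accompanies these numbers to explain them.

From the compounds shown here alone, it remains open whether a plain phenyl ring or pyridin-3-yl, with its single ring nitrogen, would fall with the five-membered rings or with pyrimidin-5-yl. Going by these compounds, it is also open how an amine or a carboxylic acid on the thiophene ring would shift the number.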